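A few compounds are considered here, and "the series" means these few. Any claim that something is new, unique, unknown or untested is made for them only; others in the source may bear on it.

Values in a functional assay on KG-1 cells (Homo sapiens) for cytotoxicity, read by luminescence and CellTiter-Glo, with a stated time of 3 days; a lower number here means a stronger inhibitor, a higher number a weaker inhibitor:
compound 1 `N#Cc1ccc(NC(=O)c2ccc3cccnc3c2O)cc1`: 2320 nM
compound 2 `O=C(Nc1ccc(Cl)cc1)c1ccc2cccnc2c1O`: 3300 nM
compound 3 `N#Cc1ccc(NC(=O)c2ccc3cccnc3c2O)c(C#N)c1`: 3770 nM

The three numbers in this assay lie close together. From compound 1 to compound 2 the change is chloro in place of cyano on an aromatic carbon; the step is a 1.4-fold higher number from compound 1 to compound 2 (0.15 log units; within the scatter). From compound 1 to compound 3 the change is cyano in place of hydrogen on an aromatic carbon; the step is a 1.6-fold higher number from compound 1 to compound 3 (0.21 log units; within the scatter). Neither step says anything beyond the scatter.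

Compound 4 `N#Cc1ccc(NC(=O)c2ccc3cccnc3c2O)c(Cl)c1` is not yet measured. It differs from compound 3 by chloro in place of cyano on an aromatic carbon. The same kind of change, chloro in place of cyano on an aromatic carbon, is seen from compound 1 to compound 2, where it gave a 1.4-fold higher number from compound 1 to compound 2 (0.15 log units; within the scatter). The two cores differ by cyano in place of hydrogen on an aromatic carbon, and the place is not the same: in compound 1 it is para to a large group, in compound 3 it is ortho to a large group and meta to a cyano group. So the change is of the same kind, not the same.

Among the compounds with values here, still, the one measured instance is the only guide. Compound 4 is expected to move by about a 1.3-fold higher number from compound 3 to compound 4 (0.12 log units; within the scatter), resting on the small step of a 1.4-fold higher number from compound 1 to compound 2 (0.15 log units; within the scatter) in compound 1 and compound 2. The estimate for compound 4 is 5000 nM, expected between 2500 nM and 10000 nM.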

Compound 4, half-maximal inhibitory concentration: 3670 nM
Compound 4: the middle estimate sits 1.4-fold (0.13 log units) above what was measured; the range from low to high includes it.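

In this assay, chloro in place of cyano on an aromatic carbon now stands on two cores, and the two steps can be set side by side: the same change on two cores in this assay, a 1.4-fold higher number (0.15 log units; within the scatter) from compound 1 to compound 2 and a 1.0-fold lower number (0.01 log units; within the scatter) from compound 3 to compound 4, 1.5-fold (0.16 log units) apart, within the scatter of two such steps. The new step on the core of compound 3 is a 1.0-fold lower number from compound 3 to compound 4 (0.01 log units; within the scatter) and the step that puts chloro where hydrogen stood is a 1.6-fold higher number from compound 1 to compound 4 (0.20 log units; within the scatter), so neither exchange separates these compounds in this readout. This shows that the exchange of cyano for chloro stayed within the scatter on both cores, but it does not show a shared effect of that exchange or fix a direction for it, and two small steps in a single assay give no basis for a rule beyond compounds 1 to 4.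

The compounds shown leave open whether an amine or a carboxylic acid on this six-membered aromatic ring would give a step beyond the scatter. They also leave open how a longer chain in that place would read, and whether the cyano-for-chloro exchange would carry over to such compounds.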